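A few compounds are considered here, and "the series" means these few. Any claim that something is new, unique, unknown or untested is made for them only; others in the source may bear on it.

Of the compounds shown here, three that share one core have been tested in a functional assay on PC-3 cells (Homo sapiens) for cytotoxicity, read by MTT assay, with a stated time of 48 h; on this read-out higher numbers stand for weaker inhibition and lower numbers for stronger inhibition. Compound 1 `O=C(CCl)N1N=C(c2cc3ccccc3oc2=O)CC1c1ccccc1` gives 2980 nM. Compound 2 `O=C(c1ccccc1Cl)N1N=C(c2cc3ccccc3oc2=O)CC1c1ccccc1` gives 6370 nM, and compound 3 `CCNCC(=O)N1N=C(c2cc3ccccc3oc2=O)CC1c1ccccc1` gives 5580 nM. Compound 3 thus holds the second highest of the three numbers; its nearest neighbour is compound 2, as a 1.1-fold lower number from compound 2 to compound 3 (0.06 log units; within the scatter), and the furthest is compound 1, as a 1.9-fold higher number from compound 1 to compound 3 (0.27 log units; within the scatter). Compound 4 `CC(C)CNCC(=O)N1N=C(c2cc3ccccc3oc2=O)CC1c1ccccc1` differs from compound 3 in one place: isopropyl in place of methyl on a saturated chain carbon bound to an amine nitrogen. Among the measured compounds shown here, the measured step that touches this part of the molecule is the one from compound 1 to compound 3, which swapped chloro for ethylamino on the saturated chain carbon bound to the carbonyl carbon and stayed within the scatter; the step between compound 2 and compound 3 also stayed within the scatter. For the measured compounds named here, no measured step alters the group carried by the amine nitrogen itself, so no step beyond the scatter is expected in this assay in either direction. The expected step is a 1.0-fold lower number from compound 3 to compound 4 (0.01 log units; within the scatter). Compound 4 is therefore estimated at 5500 nM, with a range from 2500 nM to 12000 nM.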

Compound 4, half-maximal inhibitory concentration: 1920 nM
Beside the measured number, compound 4's estimate is 2.9-fold (0.46 log units) above it, outside the stated range (below it).
By their numbers in this assay, from the lowest: compounds 4, 1, 3 and 2 (each within the scatter of the next, the first and the last beyond it).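

In this assay, among the compounds shown here, the group carried by the amine nitrogen turns out to matter: isobutylamino in place of ethylamino gives a 2.9-fold lower number from compound 3 to compound 4 (0.46 log units; beyond the scatter) and so moves the number beyond the scatter, which no earlier step among compounds 1, 2 and 3 did. The swap of 2-chlorophenyl on the carbonyl carbon for (isobutylamino)methyl also clears the scatter with a 3.3-fold lower number from compound 2 to compound 4 (0.52 log units; beyond the scatter) and thereby differs from the (ethylamino)methyl swap, while isobutylamino in place of chloro gives a 1.6-fold lower number from compound 1 to compound 4 (0.19 log units; within the scatter) and leaves those two compounds level. Nothing available here explains why this change has this effect.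

From the compounds shown here alone, two amines cannot establish a trend, so it stays open whether a longer chain such as hexylamino would continue in the same direction. A ring-bearing amine such as cyclohexylamino or a morpholine could also show whether the shape of the group counts.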